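Fluoro for propylsulfonyl on the aminopyrimidine of compound 3

The source may hold more compounds than are shown below. What is called first, only, known or untested is meant among the compounds shown, and "the series" means these compounds.

Compound 1, `OCc1ccc(-c2nn(Cc3ccccc3F)c3ncccc23)o1`, gives 1700 nM; 1700 nM (2 entries) in a functional assay (aorta) with Oryctolagus cuniculus as the target; on this read-out higher numbers stand for weaker inhibition and lower numbers for stronger inhibition. Compound 2, `Nc1ccnc(-c2nn(Cc3ccccc3F)c3ncccc23)n1`, gives 270 nM; 265000 nM (2 entries) in this assay, two entries that lie far apart, see (the several entries of compound 2 in this assay, 270 nM; 265000 nM (2 entries)). Among the compounds with values here, compound 3, `CCCS(=O)(=O)c1cnc(-c2nn(Cc3ccccc3F)c3ncccc23)nc1N`, gives 378000 nM in this assay; this is its only number. Two further determinations of compound 3 in this assay did not return a single number. On the numbers shown, compound 3 stands as the weakest inhibitor of the three, well beyond the scatter from both entries of compound 1 and from the lower entry of compound 2.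

Compound 4, `Nc1nc(-c2nn(Cc3ccccc3F)c3ncccc23)ncc1F`, is not yet measured. It differs from compound 3 by fluoro in place of propylsulfonyl on an aromatic carbon. Within the data shown here, no step between measured compounds that differ in one place is known here, so the size of this change has to be guessed. Compound 4 carries a small substituent where compound 3 carries a larger one, and in this respect it sits closer to compound 2, whose two entries span a very wide interval. The step from compound 3 to compound 4 is expected to be a 13-fold lower number from compound 3 to compound 4 (1.10 log units; beyond the scatter), towards stronger inhibition. Compound 4 is estimated at 30000 nM, within 1500 nM to 300000 nM, with a real chance that only a limit is reported.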

Compound 4, half-maximal inhibitory concentration: 478000 nM
Compound 4: middle estimate off by 16-fold (1.20 log units), on the low side; measured number outside the range, above it.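

With the step of a 1.3-fold higher number from compound 3 to compound 4 (0.10 log units; within the scatter) in this assay, the exchange of propylsulfonyl for fluoro on this aromatic carbon, ortho to the amino group, does not separate the two compounds. A group of 6 heavy atoms with 2 hydrogen-bond acceptors and a group of 1 heavy atom with none give numbers within the scatter of each other, so this pair shows no dependence of the read-out on either count. The number of compound 3, 378000 nM, therefore cannot be laid on the propylsulfonyl group in particular, since fluoro at the same place leaves it where it stands.

As far as these compounds go, whether any group at this carbon moves the number at all stays open, and the steps from compound 2, which carries neither group there, to compound 3 and compound 4 cannot be read, its entries lying far apart: the several entries of compound 2 in this assay, 270 nM; 265000 nM (2 entries) Also open is how an amine, a carboxylic acid or a longer chain at this carbon would read in this assay, and whether either would leave the number in the same place.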